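Swapping the hydroxycarbamoyl end for a methylcarbamoyl chain

This account rests on a few compounds, and the source may have more. Where it says the series, first, only, none or still open, it means among the compounds named here.

Measured so far:
Compound 1 `Nc1ncnc2c1c(-c1cnc3[nH]ccc3c1)nn2CCCCCCCCCC(=O)NO`: 10100 nM
Compound 2 `Nc1ncnc2c1c(-c1cnc3[nH]ccc3c1)nn2CCCCCC(=O)NO`: > 100000 nM
Compound 3 `Nc1nc2cc(-c3nn(CCCCCCC(=O)NO)c4ncnc(N)c34)ccc2o1`: 5710 nM

All three were tested in a functional assay on Huh-7 cells (Homo sapiens) for inhibition, read by MTT assay, with a stated time of 72 h; on this read-out higher numbers stand for weaker inhibition and lower numbers for stronger inhibition. Compound 1 gives 10100 nM and compound 3 gives 5710 nM. For compound 2 the result is only a limit of the assay, > 100000 nM, so no number is known for it; it stands at the limit of > 100000 nM in this assay, at which 1 of the 3 values shown sits, the weaker end of everything shown. For the measured compounds named here, the one measured step that touches it is an at least 9.9-fold higher number from compound 1 to compound 2 (0.99 log units; beyond the scatter), where shortening the chain carrying the hydroxycarbamoyl group moved the value from a number to the limit.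

Compound 4 `CNC(=O)CCCCCCCn1nc(-c2cnc3[nH]ccc3c2)c2c(N)ncnc21` differs from compound 2 by 2-(methylcarbamoyl)ethyl in place of hydroxycarbamoyl on a saturated chain carbon, five bonds along the chain from an aromatic nitrogen. This is not a further shortening but a replacement: the hydroxycarbamoyl group goes, and a 2-(methylcarbamoyl)ethyl chain enters in its place. Going by the values given here, no measured pair shows exactly this exchange, and the only step that bears on the end of this chain is the one from compound 1 to compound 2, which already reached the limit.

Compound 4 is therefore expected to stay at or beyond that limit in this assay, with an estimated 150000 nM spanning 30000 nM to 500000 nM, a step that the limit leaves unreadable from compound 2 to compound 4 that is expected to be unresolved.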

Compound 4, half-maximal inhibitory concentration: 23500 nM
Estimate against measurement, compound 4: 6.4-fold (0.81 log units) above; measured number outside the range, below it.
By their numbers in this assay, from the lowest: compounds 3 and 1 (each within the scatter of the next); then compound 4. At a limit, above all of these: compound 2.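

In this assay, a chain ending in methylcarbamoyl, with no hydroxycarbamoyl group at all, still gives a real number, and the exchange on this saturated chain carbon, five bonds along the chain from an aromatic nitrogen, brings an at least 4.2-fold lower number from compound 2 to compound 4 (0.62 log units; beyond the scatter). Measured against the other hydroxycarbamoyl compound, putting methylcarbamoyl in place of 2-(hydroxycarbamoyl)ethyl gives a 2.3-fold higher number from compound 1 to compound 4 (0.37 log units; beyond the scatter), a modest step, so among these compounds the hydroxycarbamoyl group is not needed for a measurable value. Compound 2 remains a limit of the assay and not a number, which leaves the true size of its step open: the limit of > 100000 nM in this assay, at which 1 of the 4 values shown sits.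

Compound 4 changes the length of the chain and its end group at once, so the compounds shown cannot separate what each of the two contributes to the result. A carboxylic acid or an unsubstituted carbamoyl group at the end of the same chain, or a hydroxycarbamoyl group on a chain matching that of compound 4, would be needed to pull these two apart.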